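A few compounds are considered here, and "the series" means these few. Any claim that something is new, unique, unknown or untested is made for them only; others in the source may bear on it.

Measured compounds in a functional assay on HEK293 cells for agonist activity at Glucose-dependent insulinotropic receptor (Homo sapiens), read by TR-FRET and cAMP accumulation, with a stated time of 60 min; a lower number here means that less compound is needed, a higher number that more compound is needed for the effect:
compound 1, `CC(C)(C)OC(=O)N1CC2CC(Oc3ncnc(Nc4ccc(S(C)(=O)=O)cc4F)c3[N+](=O)[O-])C1C2`: 77.7 nM
compound 2, `CC(C)(C)OC(=O)N1CC2CC(Oc3ncnc(Nc4ccc(S(C)(=O)=O)cc4)c3[N+](=O)[O-])C1C2`: 315 nM
compound 3, `CC(C)(C)OC(=O)N1CC2CC1CC2Oc1ncnc(Nc2ccc(S(C)(=O)=O)cc2F)c1[N+](=O)[O-]`: 5.6 nM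

Compound 3 stands lowest of the three numbers in this assay; its nearest neighbour is compound 1, and compound 2 lies furthest away, both gaps beyond the scatter. Compound 4, `CC(C)(C)OC(=O)N1CC2CC1CC2Oc1ncnc(Nc2ccc(S(C)(=O)=O)cc2)c1[N+](=O)[O-]`, has not yet been measured. It differs from compound 3 in one place: hydrogen in place of fluoro on an aromatic carbon. Among the compounds with values here, one measured step bears directly on this change. Compound 1 and compound 2 differ in exactly the same way on a closely related core, and there a 4.1-fold higher number from compound 1 to compound 2 (0.61 log units; beyond the scatter). Within the data shown here, only this single pair is available, so the size of the step cannot be checked against a second example. Taken at face value, the same change on the core of compound 3 is expected to move the number in the same direction and by a similar, modest amount, beyond the scatter. For compound 4 in this assay the expected value is therefore 23 nM, with a range from 9 nM to 60 nM. This estimate means an expected step of a 4.1-fold higher number from compound 3 to compound 4 (0.61 log units; beyond the scatter).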

Compound 4, half-maximal effective concentration: 110 nM
Compound 4: middle estimate off by 4.8-fold (0.68 log units), on the low side, and the stated range ends below it.
By their numbers in this assay, from the lowest: compound 3; then compounds 1 and 4 (each within the scatter of the next); then compound 2.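

In this assay, the fluoro on the aromatic carbon ortho to a large group proves to matter far more on the core of compound 3 than the earlier pair could show: hydrogen in its place gives a 20-fold higher number from compound 3 to compound 4 (1.29 log units; beyond the scatter). The direction of the change holds on both cores, but its size does not carry over from one core to the other: the same change on two cores in this assay, a 4.1-fold higher number (0.61 log units; beyond the scatter) from compound 1 to compound 2 and a 20-fold higher number (1.29 log units; beyond the scatter) from compound 3 to compound 4, 4.8-fold (0.69 log units) apart, beyond the scatter of two such steps

The compounds shown hold only fluoro or hydrogen at this place, so it remains open whether a chloro or a methyl group on the same carbon would behave like fluoro on either core. These four compounds also cannot tell why the same change differs in size between the two cores, or whether that difference would persist with another group in place of the nitro group.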